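Cyano for Trifluoromethyl on Two Pyrazoline Sulfonamide Cores

A few compounds are considered here, and "the series" means these few. Any claim that something is new, unique, unknown or untested is made for them only; others in the source may bear on it.

Of the compounds shown here, three of one series have been measured in a functional assay on NCI-H1975 cells (Homo sapiens) for inhibition, read by sulforhodamine B assay, tested at 10 uM; a lower number here means less inhibition, a higher number more inhibition at the concentration tested (going by the name of the read-out). Compound 1 `CN1CCN(c2ccc(C3=NN(S(=O)(=O)c4ccc(C(F)(F)F)cc4)C(c4ccc(N(C)C)cc4)C3)cc2)CC1` gives 18.9% in this assay. Compound 2 `CN1CCN(c2ccc(C3=NN(S(=O)(=O)c4ccc(C#N)cc4)C(c4ccc(N(C)C)cc4)C3)cc2)CC1` differs from compound 1 in a single place, (cyano in place of trifluoromethyl on an aromatic carbon), and in this assay compound 2 gives 100%; the step is a number 81.1 percentage points higher from compound 1 to compound 2 (beyond the scatter). Compound 3 `CN(C)c1ccc(C2CC(c3ccc(-n4cncn4)cc3)=NN2S(=O)(=O)c2ccc(C(F)(F)F)cc2)cc1` carries a different core, which differs from that of compound 1 as follows: 1H-1,2,4-triazol-1-yl in place of 4-methylpiperazin-1-yl on an aromatic carbon. In this assay compound 3 gives 5.5%, the lowest of the three numbers, and the step is a number 13.4 percentage points lower from compound 1 to compound 3 (beyond the scatter).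

Compound 4 `CN(C)c1ccc(C2CC(c3ccc(-n4cncn4)cc3)=NN2S(=O)(=O)c2ccc(C#N)cc2)cc1` has not yet been measured in this assay. It stands to compound 3 as compound 2 stands to compound 1: cyano in place of trifluoromethyl on an aromatic carbon. The place of the change is the same in both pairs, so it is the same change, made here on the core of compound 3 instead of the core of compound 1.

The estimate for compound 4 rests on a single earlier example of this change, the step of a number 81.1 percentage points higher from compound 1 to compound 2 (beyond the scatter), and on the starting number of compound 3, 5.5%, which is the lowest in the set. Whether the second core carries the change through to the same extent is not known from these three compounds, and the upper end of the scale cuts off how much higher the number can go. Compound 4 is therefore expected to rise by a step of about a number 64.5 percentage points higher from compound 3 to compound 4 (beyond the scatter), with the uncertainty of a single precedent. The estimated value for compound 4 in this assay is 70%, between 30% and 100%.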

Compound 4, a percentage reported as inhibition, at one concentration (the size of the read-out at that concentration, not a potency): 22.6%
Estimate against measurement, compound 4: 47.4 percentage points above; measured number below the stated range.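

In this assay, cyano in place of trifluoromethyl gives a higher number on both cores, but the size of the step does not carry over: on the core of compound 3 it is a number 17.1 percentage points higher from compound 3 to compound 4 (beyond the scatter), well short of the earlier step on the core of compound 1: the same change on two cores in this assay, a number 81.1 percentage points higher (beyond the scatter) from compound 1 to compound 2 and a number 17.1 percentage points higher (beyond the scatter) from compound 3 to compound 4, 64 percentage points apart, beyond the scatter of two such steps. Read the other way, 1H-1,2,4-triazol-1-yl in place of 4-methylpiperazin-1-yl is a number 77.4 percentage points lower from compound 2 to compound 4 (beyond the scatter), much larger than the same exchange with trifluoromethyl in the molecule: the same change on two cores in this assay, a number 13.4 percentage points lower (beyond the scatter) from compound 1 to compound 3 and a number 77.4 percentage points lower (beyond the scatter) from compound 2 to compound 4, 64 percentage points apart, beyond the scatter of two such steps. The two changes are therefore not independent in these four compounds, with the high number of compound 2 appearing only where cyano and 4-methylpiperazin-1-yl occur together, but four compounds at a single tested concentration do not show why this is so, nor whether it holds on any other core.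

The compounds shown leave open whether the high number depends on the 4-methylpiperazin-1-yl group in particular or would also appear with another amine in its place, such as a morpholine or a dimethylamino group. They also leave open whether a group other than cyano on the sulfonyl-bearing phenyl ring, such as a nitro group or a carboxylic acid, would behave in the same way on either core.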